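Cyclohexyl to phenyl on the thioamide series

This account rests on a few compounds, and the source may have more. Where it says the series, first, only, none or still open, it means among the compounds named here.

Measured so far:
Compound 1 `Cc1cc(O)c(C(=S)NC2CCCCC2)c(=O)o1`: 177000 nM
Compound 2 `Cc1cc(O)c(C(=O)Nc2ccc(OCc3ccccc3)cc2)c(=O)o1`: > 200000 nM (a limit)

Going by the values given here, in an ADME assay on L929 cells (Mus musculus, culture collection number NCTC 929) for cytotoxicity, read by MTT assay, with a stated time of 72 h (on this read-out lower numbers stand for stronger inhibition and higher numbers for weaker inhibition), compound 1 gives 177000 nM, the only actual number so far. Compound 2 stands at > 200000 nM, which is a limit of the assay. Compound 3 `Cc1cc(O)c(C(=S)Nc2ccccc2)c(=O)o1` is still unmeasured and differs from compound 1 by phenyl in place of cyclohexyl on an amide-type nitrogen. Among the compounds with values here, no measured step covers this change, and no shift beyond the usual scatter is expected in this assay. The expected step is a 1.4-fold lower number from compound 1 to compound 3 (0.13 log units; within the scatter). For compound 3 the estimate is 130000 nM, with an expected range from 50000 nM to 200000 nM.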

Compound 3, half-maximal inhibitory concentration: > 200000 nM
Compound 3 was reported as a limit; the forecaster's own chance of this, stated with the estimate: 30%; middle value at least 1.5-fold (0.18 log units) from the limit.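

In this assay, phenyl in place of cyclohexyl on an amide-type nitrogen gives an at least 1.1-fold higher number from compound 1 to compound 3 (0.05 log units; that floor lies within the scatter), the first step read at this position, and its floor lies within the scatter. Compound 3 is a limit of the assay, not a number. The true size of the step stays unknown because the read-out for compound 3 stops at that limit: the limit of > 200000 nM in this assay, at which 2 of the 3 values shown sit.

Still open, on these data alone, is whether a longer alkyl chain on this nitrogen, or a phenyl carrying an amine or a carboxylic acid, gives a number clear of that limit.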